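Benzyl variation on the imidazole arm of the series

The source may hold more compounds than are shown below. What is called first, only, known or untested is meant among the compounds shown, and "the series" means these compounds.

In a functional assay on NIH3T3 cells (Mus musculus) (on this read-out lower numbers stand for an effect already at smaller amounts and higher numbers for an effect only at larger amounts of compound), compound 1 `CSCC[C@H](NC(=O)c1ccc(NCc2cncn2Cc2cccc(C#N)c2)cc1-c1ccccc1)C(=O)O` gives > 10 uM, which is a limit of the assay rather than a number. Compound 2 `CSCC[C@H](NC(=O)c1ccc(NCc2cncn2Cc2ccccc2C)cc1-c1ccccc1)C(=O)O` likewise reaches only the limit, > 10 uM. Compound 3 `N#Cc1ccc(Cn2cncc2CNc2ccc(C(=O)NCc3ccccc3)c(-c3ccccc3)c2)cc1` also returns a limit, > 10 uM. The step that the two limits leave unreadable from compound 1 to compound 2 therefore has no readable size. Compound 2 thus stands at the limit of > 10 uM in this assay, at which 3 of the 3 values shown sit, so no number places it within the series. Compound 4 `CSCC[C@H](NC(=O)c1ccc(NCc2cncn2Cc2cccc(Cl)c2)cc1-c1ccccc1)C(=O)O` differs from compound 2 by 3-chlorophenyl in place of 2-methylphenyl on a saturated chain carbon bound to an aromatic nitrogen. Among the measured compounds shown here, the only measured step at this position is the unreadable one already named, so no direction or size can be set for the new step in this assay. Compound 4 is therefore expected to sit near the limit as well, at 15 uM, between 5 uM and 50 uM. The expected step that the limit leaves unreadable from compound 2 to compound 4 is estimated to lie within the scatter.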

Compound 4, concentration for half-maximal effect: > 10 uM
Compound 4: no number, only a limit (the forecaster's own chance of this, stated with the estimate: 80%); the middle value does not contradict the limit.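

Among the compounds shown here, compound 4 gives > 10 uM, again a limit and not a number, so no step to compound 4 from compound 1 or compound 2 can be read: the limit of > 10 uM in this assay, at which 4 of the 4 values shown sit. The compounds shown leave open how 2-methylbenzyl and 3-chlorobenzyl compare, and what number any of these compounds would give.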